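Swapping a Fluorophenyl Sulfonyl for a Pyridinyl Sulfonyl

A few compounds are considered here, and "the series" means these few. Any claim that something is new, unique, unknown or untested is made for them only; others in the source may bear on it.

In an assay on isolated protein for activation of Insulin-degrading enzyme (Homo sapiens), read by fluorescence, with stated times of 10 min and 20 min (on this read-out lower numbers stand for an effect already at smaller amounts and higher numbers for an effect only at larger amounts of compound), compound 2 `O=C(CCCc1cn(S(=O)(=O)c2ccc(F)cc2)c2ccccc12)NCCCn1ccnc1` gives 6760 nM. Among the compounds with values here, its only measured neighbour, compound 1 `O=C(CCCc1cn(S(=O)(=O)c2cccc(F)c2)c2ccccc12)NCCCn1ccnc1`, gives 10200 nM, and the two numbers lie within the scatter of each other. The change to compound 3 `O=C(CCCc1cn(S(=O)(=O)c2cccnc2)c2ccccc12)NCCCn1ccnc1` is pyridin-3-yl in place of 4-fluorophenyl on a sulfonyl sulfur. Within the data shown here, the one measured step, a 1.5-fold lower number from compound 1 to compound 2 (0.18 log units; within the scatter), shifted only the position of the fluorine and stayed within the scatter; no measured step exchanges the ring itself, so nothing here points in a direction. The expected step is therefore small, a 1.2-fold higher number from compound 2 to compound 3 (0.07 log units; within the scatter). The estimate for compound 3 is 8000 nM, with a range from 3000 nM to 25000 nM.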

Compound 3, half-maximal effective concentration: 26900 nM
Compound 3: middle estimate off by 3.4-fold (0.53 log units), on the low side; the measured number lies above the stated range.
By their numbers in this assay, from the lowest: compounds 2 and 1 (each within the scatter of the next); then compound 3.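

Exchanging the fluorophenyl ring on the sulfonyl sulfur for pyridin-3-yl raises the number in this assay: the change gives a 4.0-fold higher number from compound 2 to compound 3 (0.60 log units; beyond the scatter), and a 2.6-fold higher number from compound 1 to compound 3 (0.42 log units; beyond the scatter), so more compound is needed for the same effect. This position therefore responds to a change of the ring itself, which moving the fluorine alone did not show. No measurement here explains this shift.

Going by these compounds, it remains open whether the ring nitrogen or the missing fluorine accounts for the step. A plain phenyl ring at this position would separate the two.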